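Exposure notes on the step to compound 3

The source may report more compounds than this note shows. Statements on the series, on what has been measured and on what is new or still open speak of the compounds shown alone.

For the measured compounds named here, in an ADME assay on the whole organism (plasma, Rattus norvegicus, strain Sprague-Dawley) for pharmacokinetics, read by LC-MS, with a stated time of 4 h, at a dose of 15 mg/kg by the intraduodenal route (on this read-out higher numbers stand for higher exposure at the dose given and lower numbers for lower exposure), compound 1 `C=C[C@@H]1C[C@]1(NC(=O)[C@@H]1C[C@@H](Oc2cc(-c3ccccc3)nc3cc(OC)ccc23)CN1C(=O)[C@@H](NC(=O)OC(C)(C)C)C(C)(C)C)C(=O)NS(=O)(=O)C1CC1` gives 61 ng.h/mL, the only number so far. For compound 2 `C=C[C@@H]1C[C@]1(NC(=O)[C@@H]1C[C@@H](Oc2cc(-c3ccccc3)nc3cc(OC)ccc23)CN1C(=O)[C@H]([C@@H](C)CC)N(C)C(=O)NC1CCCC1)C(=O)NS(=O)(=O)C1CC1` the entry reads "not determined" (no result reported). Compound 3 `C=C[C@@H]1C[C@]1(NC(=O)[C@@H]1C[C@@H](Oc2cc(-c3ccccc3)nc3cc(OC)ccc23)CN1C(=O)[C@@H](OC(=O)NC1CCCC1)C(C)(C)C)C(=O)NS(=O)(=O)C1CC1` carries (cyclopentylcarbamoyl)oxy in place of (tert-butoxycarbonyl)amino on a saturated chain carbon bound to a carbonyl carbon and a saturated chain carbon. Going by the values given here, no measured step shows what such a change does, so no direction is favoured. In this assay the expected step of a 1.0-fold lower number from compound 1 to compound 3 (0.01 log units; within the scatter) stays within the usual scatter. The estimated value for compound 3 is 60 ng.h/mL, with an expected range of 20 ng.h/mL to 180 ng.h/mL.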

Compound 3, area under the concentration-time curve: 95 ng.h/mL
For compound 3 the middle estimate is 1.6-fold (0.20 log units) below the measured one; the range from low to high includes it.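

In this assay, for the compounds shown here, the first readable step on a saturated chain carbon bound to a carbonyl carbon and a saturated chain carbon is a 1.6-fold higher number from compound 1 to compound 3 (0.19 log units; within the scatter). Exchanging (tert-butoxycarbonyl)amino for (cyclopentylcarbamoyl)oxy, with its five-membered non-aromatic ring of carbon only, therefore leaves the reading within the scatter. Nothing available explains this reading. Going by these compounds alone, compound 2 gives no step that can be read. On these data alone, how an amine or a carboxylic acid in place of (cyclopentylcarbamoyl)oxy would read in this assay remains open.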